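Methyl to methoxy on the bromo cinnamamide series

The compounds below may be only part of what the source reports. "The series", "measured", "known", "first", "only" and "open" are said of these compounds alone.

Measured in a functional assay on MCF7 cells (Homo sapiens) for antiproliferative activity, read by MTT assay, with a stated time of 48 h; a higher number here means a weaker inhibitor, a lower number a stronger inhibitor:
- compound 1 `COc1ccc(/C=C/C(=O)Nc2nnc(-c3ccc(C)cc3)s2)cc1`: 0.35 ug/mL
- compound 2 `O=C(/C=C/c1ccccc1)Nc1nnc(-c2ccc(Br)cc2)s1`: 1.5 ug/mL
- compound 3 `Cc1ccc(/C=C/C(=O)Nc2nnc(-c3ccc(Br)cc3)s2)cc1`: 1.32 ug/mL
- compound 4 `COc1ccc(/C=C/C(=O)Nc2nnc(-c3ccc(Br)cc3)s2)cc1`: not yet measured

Compound 3, at 1.32 ug/mL, is second highest of the three numbers. It lies within the scatter of compound 2, at 1.5 ug/mL, and well apart from compound 1, at 0.35 ug/mL, which lies lower by more than the scatter.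

The next step replaces the methyl of compound 3 to give compound 4: methoxy in place of methyl on an aromatic carbon. In words, this is methoxy in place of methyl on an aromatic carbon.

Among the measured compounds shown here, only one measured step touches the same place: a 1.1-fold lower number from compound 2 to compound 3 (0.06 log units; within the scatter). That step is small and says little about a further change there. For the measured compounds named here, compound 1, at 0.35 ug/mL, is the only measured compound with the methoxy group, but it also differs from compound 4 elsewhere, so no measured step isolates this group. Its low value still tilts the expectation slightly downward in this assay.

The expected change is modest, with a 1.5-fold lower number from compound 3 to compound 4 (0.17 log units; within the scatter) as the estimated step, and a result within the scatter would be unsurprising. For compound 4 the estimate is 0.9 ug/mL, with an expected range from 0.3 ug/mL to 2.2 ug/mL.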

Compound 4, half-maximal inhibitory concentration: 1.13 ug/mL
Compound 4: the middle estimate sits 1.3-fold (0.10 log units) below what was measured, within the range that was stated.
By their numbers in this assay, from the lowest: compound 1; then compounds 4, 3 and 2 (each within the scatter of the next).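

Within the bromo compounds in this assay, the position on the aromatic carbon para to a large group has so far shown no response to the change from methyl to methoxy: a 1.2-fold lower number from compound 3 to compound 4 (0.07 log units; within the scatter). Hydrogen at the same place gives the same picture, with a 1.3-fold lower number from compound 2 to compound 4 (0.12 log units; within the scatter), so compound 2, compound 3 and compound 4 form one group within the scatter, and the three substituents cannot be ranked. Among the compounds shown here, with methoxy held fixed, a 3.2-fold higher number from compound 1 to compound 4 (0.51 log units; beyond the scatter) is the only new step beyond the scatter, which places the difference in this set at the swap of bromo for methyl and not at the methoxy position; nothing on hand accounts for either result.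

With methyl in place of bromo, only the methoxy compound is shown, so it remains open whether hydrogen, methyl and methoxy would also fall within the scatter of one another on that background. Also open, as far as these compounds go, is whether an amine, a carboxylic acid or a longer chain such as butoxy at this position would give a step beyond the scatter in this assay.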